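The compounds below may be only part of what the source reports. "The series", "measured", "known", "first", "only" and "open" are said of these compounds alone.

Series notes. In an assay for inhibition of transient receptor potential cation channel subfamily V member 1 (Rattus norvegicus), with a stated time of 10 min (on this read-out higher numbers stand for weaker inhibition and lower numbers for stronger inhibition), compound 1 `CCc1ccc(C/N=C(\S)NCc2ccc(NS(C)(=O)=O)c(F)c2)cc1` gives 1100 nM, and compound 2 `CC(C)c1ccc(C/N=C(\S)NCc2ccc(NS(C)(=O)=O)c(F)c2)cc1` gives 520 nM; the change between them is methyl in place of hydrogen on a saturated chain carbon bound to an aromatic carbon and a saturated chain carbon, and it made a 2.1-fold lower number from compound 1 to compound 2 (0.33 log units; beyond the scatter). Within the data shown here, compound 3 `COC(=O)CNc1ccc(C/N=C(\S)NCc2ccc(C(C)(C)C)cc2)cc1F` carries a different core, and the difference between the two cores is not broken down here; in this assay compound 3 gives 3600 nM, the highest of the three numbers so far. Compound 4 `CCOC(=O)CNc1ccc(C/N=C(\S)NCc2ccc(C(C)(C)C)cc2)cc1F` is the next member; the change from compound 3 is methyl in place of hydrogen on a saturated chain carbon bound to an oxygen next to a carbonyl group. It is the same kind of change as the step from compound 1 to compound 2, but the place differs: on a saturated chain carbon bound to an oxygen next to a carbonyl group, rather than on a saturated chain carbon bound to an aromatic carbon and a saturated chain carbon, and the core is different as well. Among the measured compounds shown here, a smaller step than the earlier one is expected, a 1.3-fold lower number from compound 3 to compound 4 (0.11 log units; within the scatter), because the only precedent, a 2.1-fold lower number from compound 1 to compound 2 (0.33 log units; beyond the scatter), was itself modest and sits at another place. For compound 4 in this assay the estimate is 2800 nM, with a range from 1200 nM to 6500 nM.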

Compound 4, half-maximal inhibitory concentration: > 30000 nM
Compound 4 ended at the assay's limit; the forecaster's own chance of this, stated with the estimate: 5%; middle value at least 10-fold (1.02 log units) away from the limit.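

In this assay compound 4 reads > 30000 nM, which is a limit of the assay and not a number. The methyl-for-hydrogen change does not carry over between these cores, with an at least 8.3-fold higher number from compound 3 to compound 4 (0.92 log units; beyond the scatter) running opposite to the earlier step: the same change on two cores in this assay, a 2.1-fold lower number (0.33 log units; beyond the scatter) from compound 1 to compound 2 and an at least 8.3-fold higher number (0.92 log units; beyond the scatter) from compound 3 to compound 4, at least 17-fold (1.24 log units) apart, beyond the scatter of two such steps The two pairs differ in the place of the change as well as in core, and these data do not separate the two, nor do they give the full size of the newer step. Open, on these data alone, is how a carboxylic acid, an amide or a longer chain in place of methoxycarbonyl would read on the core of compound 3. Also open, as far as these compounds go, is whether the methyl change behaves alike at one shared place on both cores.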